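Swapping fluoro for bromo on a diaryl thiophene amide

This account rests on a few compounds, and the source may have more. Where it says the series, first, only, none or still open, it means among the compounds named here.

Three compounds share a core that carries an amino group, a carbonyl-linked amide and two aryl rings. Compound 1 `Nc1sc(-c2ccccc2)c(-c2ccc(Cl)cc2)c1C(=O)NC1CC1` gives 17100 nM in a functional assay on PC-3 cells (Homo sapiens) for cytotoxicity, read by sulforhodamine B assay, with a stated time of 72 h; a lower number here means a stronger inhibitor, a higher number a weaker inhibitor. Compound 2 `Nc1sc(-c2ccc(F)cc2)c(-c2ccc(Cl)cc2)c1C(=O)N1CCCC1` gives 20400 nM in this assay, and compound 3 `Nc1sc(-c2ccc(F)cc2)c(-c2ccc(Cl)cc2)c1C(=O)NCc1ccccc1` gives 25800 nM. Compound 3 has the highest of the three numbers, yet its gaps to compound 2 and to compound 1 both lie within the scatter, so no order among them can be read.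

Compound 4 `Nc1sc(-c2ccc(Br)cc2)c(-c2ccc(Cl)cc2)c1C(=O)NCc1ccccc1` differs from compound 3 in one place: bromo in place of fluoro on an aromatic carbon. The only step that is shown, a 1.3-fold higher number from compound 2 to compound 3 (0.10 log units; within the scatter), concerns the amide end and not the halogen-bearing ring, so it does not bear on this change. Compound 1, which carries an unsubstituted phenyl at that position, also differs from compound 3 at the amide, so its value gives no clean guide either. With nothing in the data pointing to a shift in either direction, compound 4 is expected to land close to compound 3, and the step of a 1.2-fold lower number from compound 3 to compound 4 (0.07 log units; within the scatter) is estimated to stay within the scatter. Compound 4 is therefore expected to give about 22000 nM in this assay, between 9000 nM and 55000 nM.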

Compound 4, half-maximal inhibitory concentration: > 50000 nM
Compound 4 gave a limit, no number; the forecaster's own chance of this, stated with the estimate: 10%; at least 2.2-fold (0.35 log units) between middle value and limit.
By their numbers in this assay, from the lowest: compounds 1, 2 and 3 (each within the scatter of the next). At a limit, above all of these: compound 4.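

Among these compounds, with the benzylamino amide held fixed, the change from 4-fluorophenyl to 4-bromophenyl is the first one here made at this aromatic carbon alone, and it gives an at least 1.9-fold higher number from compound 3 to compound 4 (0.28 log units; that floor lies within the scatter). Compound 4 gives a limit and not a number: the limit of > 50000 nM in this assay, at which 1 of the 4 values shown sits. Among the compounds shown here, the pair therefore shows that bromo at this position brings no gain over fluoro in this assay, something the earlier compounds could not show, but the step is only a floor, and since that floor lies within the scatter, it does not establish a loss beyond the scatter.

Going by these compounds, whether the same exchange would read alike on the pyrrolidin-1-yl amide of compound 2 stays open, so the limit cannot be assigned to bromo in general rather than to bromo together with the benzylamino amide. Also open, on these data alone, is how a methoxy group or an amine at this same place on the ring would read, and so whether the fluoro of compound 3 is itself needed for a measurable value.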